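From Methoxymethoxy to Bromo on a Shared Core

The source may hold more compounds than are shown below. What is called first, only, known or untested is meant among the compounds shown, and "the series" means these compounds.

Compound 1 (`C=CCOc1cc(/C=C\c2cc(OC)c(OC)c(OC)c2)ccc1OC`) gives 43500 nM in an ADME assay on HEK293 cells (Homo sapiens) for inhibition, read by MTT assay, with a stated time of 3 days; a higher number here means a weaker inhibitor, a lower number a stronger inhibitor
Compound 2 (`COCOc1ccc(/C=C/CCCOc2cc(/C=C\c3cc(OC)c(OC)c(OC)c3)ccc2OC)cc1`) gives 25000 nM in this assay

Compound 2 stands level with compound 1 on these numbers, since their two values lie within the usual scatter of each other and cannot be ranked. The next structure, compound 3 (`COc1ccc(/C=C\c2cc(OC)c(OC)c(OC)c2)cc1OCCC/C=C/c1ccc(Br)cc1`), has not yet been measured. The change from compound 2 is bromo in place of methoxymethoxy on an aromatic carbon and amounts to bromo in place of methoxymethoxy on an aromatic carbon of a six-membered aromatic ring of carbon only, para to a large group.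

Within the data shown here, no measured pair in this small set isolates a change at that place, so the data give no direct guide to its size or direction. The only indication is indirect: compound 1 at 43500 nM and compound 2 at 25000 nM sit within the scatter of each other despite their different structures. Expected for this change is a 1.1-fold lower number from compound 2 to compound 3 (0.06 log units; within the scatter) and so nothing beyond the scatter. For compound 3 the estimated value in this assay is 22000 nM (expected range 9000 nM to 50000 nM).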

Compound 3, half-maximal inhibitory concentration: 55000 nM
Compound 3: middle estimate off by 2.5-fold (0.40 log units), on the low side, outside the stated range (above it).
By their numbers in this assay, from the lowest: compounds 2, 1 and 3 (each within the scatter of the next, the first and the last beyond it).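

In this assay, among these compounds, bromo in place of methoxymethoxy on an aromatic carbon, para to a large group, gives a 2.2-fold higher number from compound 2 to compound 3 (0.34 log units; beyond the scatter), so this is the first single change in the set to lie beyond the scatter, and it goes toward a weaker inhibitor. The larger replacement, a group of 11 heavy atoms in place of a group of 2 heavy atoms on a saturated chain carbon bound to an oxygen on an aromatic ring, gives a 1.3-fold higher number from compound 1 to compound 3 (0.10 log units; within the scatter), which lies within the scatter, so the bromo compound cannot be ranked against compound 1. Nothing measured here accounts for the modest step at the aromatic carbon.

With only two groups compared at this place, the compounds shown leave open whether the step comes from the loss of methoxymethoxy or from the arrival of bromo. They also leave open how a hydroxyl, a chloro or an amine on that same aromatic carbon would read, and whether a longer chain would change the picture.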